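This account rests on a few compounds, and the source may have more. Where it says the series, first, only, none or still open, it means among the compounds named here.

Three compounds have been measured in a functional assay on MDA-MB-468 cells (Homo sapiens) for cytotoxicity, read by resazurin assay, with a stated time of 72 h; on this read-out higher numbers stand for weaker inhibition and lower numbers for stronger inhibition:

Compound 1 `CCCCOC(=O)CCSC(=S)NCc1cccnc1`: 12800 nM
Compound 2 `CC1(C)OB(CCCSC(=S)NCc2cccnc2)OC1(C)C`: 6620 nM
Compound 3 `COc1ccc(-c2nnc(CCSC(=S)NCc3cccnc3)o2)cc1`: 5220 nM

Compound 3 shows the lowest of the three numbers. Its nearest neighbour is compound 2, whose value lies within the scatter of it, while the gap to compound 1 lies beyond the scatter. Compound 4 `S=C(NCc1cccnc1)SCCc1nnc(-c2cc3ccccc3s2)o1` has not yet been tested in this assay. It differs from compound 3 in one place: 1-benzothiophen-2-yl in place of 4-methoxyphenyl on an aromatic carbon. For the measured compounds named here, no pair of measured compounds that differ in one place is available, so this step has no direct precedent. Exchanging one aromatic group for another is expected to move the number little, and the estimated step of a 1.2-fold lower number from compound 3 to compound 4 (0.06 log units; within the scatter) is expected to stay within the scatter. For compound 4 the expected value is 4500 nM, with a range from 1500 nM to 13000 nM.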

Compound 4, half-maximal inhibitory concentration: 6770 nM
The estimate for compound 4 lay 1.5-fold (0.18 log units) below the measured number; the range from low to high includes it.
By their numbers in this assay, from the lowest: compounds 3, 2, 4 and 1 (each within the scatter of the next, the first and the last beyond it).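

In this assay, for the compounds shown here, this is the first single-place comparison, and it gives a 1.3-fold higher number from compound 3 to compound 4 (0.11 log units; within the scatter). On this aromatic carbon, therefore, 4-methoxyphenyl with one aromatic ring and 1-benzothiophen-2-yl with two cannot be told apart, though this single pair sets no rule for other groups. No available evidence offers an explanation for this result.

From the compounds shown here alone, both groups compared here are aromatic, so it remains open how the number would respond to a non-aromatic group at this place, such as cyclohexyl, an amine or a carboxylic acid.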